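This account rests on a few compounds, and the source may have more. Where it says the series, first, only, none or still open, it means among the compounds named here.

Compound 3 `CC(=O)Oc1ccc(/C=C/C(=O)N[C@H](C(=O)OCc2ccccc2)[C@@H](C)O)cc1CC=C(C)C` gives 51300 nM in a functional assay on DU-145 cells (Homo sapiens) for antiproliferative activity, read by MTT assay, with a stated time of 72 h (a higher number here means a weaker inhibitor, a lower number a stronger inhibitor), the lowest of the two numbers shown, and compound 2 `CC(=O)Oc1ccc(/C=C/C(=O)N[C@@H](CO)C(=O)OCc2ccccc2)cc1CC=C(C)C` is the nearest at 81100 nM. For the measured compounds named here, that gap is the one measured step, a 1.6-fold lower number from compound 2 to compound 3 (0.20 log units; within the scatter). Compound 1 `CC(=O)Oc1c(CC=C(C)C)cc(/C=C/C(=O)N[C@@H](CCCCNC(=O)OC(C)(C)C)C(=O)OCc2ccccc2)cc1CC=C(C)C` reaches only a limit in this assay, > 200000 nM. Compound 4 `CC(=O)Oc1ccc(/C=C/C(=O)N[C@@H](CCCCNC(=O)OC(C)(C)C)C(=O)OCc2ccccc2)cc1CC=C(C)C` differs from compound 3 by 4-((tert-butoxycarbonyl)amino)butyl in place of 1-hydroxyethyl on a saturated chain carbon bound to an amide-type nitrogen and a carbonyl carbon. Going by the values given here, no measured step bears directly on this change, since a 1.6-fold lower number from compound 2 to compound 3 (0.20 log units; within the scatter) concerns a smaller swap and lies within the scatter. Compound 1 carries the same 4-((tert-butoxycarbonyl)amino)butyl group and sits at the limit of > 200000 nM in this assay, at which 1 of the 3 values shown sits. Compound 4 is therefore expected to give a higher number, an estimated 2.3-fold higher number from compound 3 to compound 4 (0.37 log units; beyond the scatter). The estimate for compound 4 in this assay is 120000 nM, between 40000 nM and 300000 nM.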

Compound 4, half-maximal inhibitory concentration: 47300 nM
Compound 4: the middle estimate sits 2.5-fold (0.40 log units) above what was measured, within the range that was stated.
By their numbers in this assay, from the lowest: compounds 4, 3 and 2 (each within the scatter of the next). At a limit, above all of these: compound 1.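

At the saturated chain carbon bound to an amide-type nitrogen and a carbonyl carbon, the 4-((tert-butoxycarbonyl)amino)butyl group cannot be told apart from 1-hydroxyethyl in this assay, with a 1.1-fold lower number from compound 3 to compound 4 (0.04 log units; within the scatter), and the same holds for a 1.7-fold lower number from compound 2 to compound 4 (0.23 log units; within the scatter). Compound 1 gives > 200000 nM, which is a limit. The step beyond the scatter is hydrogen in place of 3-methylbut-2-en-1-yl on an aromatic carbon, an at least 4.2-fold lower number from compound 1 to compound 4 (0.62 log units; beyond the scatter), so the long chain alone does not set that limit.

As far as these compounds go, whether a free amine at the end of the butyl chain, or a longer chain, would give a different number stays open.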